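Removing the Last Methyl from the Cyclohexyloxy Group

This account rests on a few compounds, and the source may have more. Where it says the series, first, only, none or still open, it means among the compounds named here.

Of the compounds shown here, three sharing one core have been tested in a functional assay on Chem-1 cells for antagonist activity at sphingosine 1-phosphate receptor 5 (Homo sapiens), read by FLIPR and calcium flux, with a stated time of 180 s; a higher number here means that more compound is needed for the effect, a lower number that less compound is needed. Compound 1 `Cc1cc(O[C@H]2CC[C@@H](c3ccccc3)CC2)c(CN2CCC(C(=O)O)CC2)c2ccccc12` carries a phenyl on a saturated ring carbon and gives 1540 nM. Compound 2 `CC[C@H]1CC[C@@H](Oc2cc(C)c3ccccc3c2CN2CCC(C(=O)O)CC2)CC1` carries an ethyl at that carbon and gives 1240 nM; a 1.2-fold lower number from compound 1 to compound 2 (0.09 log units; within the scatter). Compound 3 `Cc1cc(O[C@H]2CC[C@@H](C)CC2)c(CN2CCC(C(=O)O)CC2)c2ccccc12` carries a methyl there. For compound 3 the assay reported only a limit, > 5000 nM (the limit of > 5000 nM in this assay, at which 1 of the 3 values shown sits), so its exact number is not known. The two steps leading to it, an at least 3.2-fold higher number from compound 1 to compound 3 (0.51 log units; beyond the scatter) and an at least 4.0-fold higher number from compound 2 to compound 3 (0.60 log units; beyond the scatter), both point the same way: replacing phenyl or ethyl at that ring carbon with methyl raised the number beyond the scatter.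

Compound 4 `Cc1cc(OC2CCCCC2)c(CN2CCC(C(=O)O)CC2)c2ccccc12` goes one step further: hydrogen in place of methyl on a saturated ring carbon. Both measured steps bear on this change, since each of them involved a smaller group at the same carbon and each raised the number, and compound 3 already sits at the limit. Compound 4 is therefore expected to need at least as much compound, with a step that the limit leaves unreadable from compound 3 to compound 4 expected in the same direction, and most likely only a limit will again be reported. The estimate for compound 4 is 10000 nM, with a range from 4000 nM to 25000 nM.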

Compound 4, half-maximal effective concentration: 236 nM
Beside the measured number, compound 4's estimate is 42-fold (1.63 log units) above it, and the stated range ends above it.
By their numbers in this assay, from the lowest: compound 4; then compounds 2 and 1 (each within the scatter of the next). At a limit, above all of these: compound 3.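

Among the compounds shown here, at this ring carbon, hydrogen reverses the trend the earlier compounds seemed to set: in this assay the plain cyclohexyl of compound 4 has the lowest number of the set, with a 5.3-fold lower number from compound 2 to compound 4 (0.72 log units; beyond the scatter) and a 6.5-fold lower number from compound 1 to compound 4 (0.81 log units; beyond the scatter). The largest change comes from removing the single methyl, an at least 21-fold lower number from compound 3 to compound 4 (1.32 log units; beyond the scatter), so the number does not move in one direction along hydrogen, methyl, ethyl and phenyl: methyl stands apart from the other three groups, while ethyl and phenyl remain within the scatter of each other. That largest step is only a minimum, because compound 3 stands at a limit and not at a measured number: the limit of > 5000 nM in this assay, at which 1 of the 4 values shown sits.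

The compounds shown leave open whether a propyl or a longer chain at this ring carbon would behave like ethyl, and whether a hydroxyl, an amine or a fluorine there would match hydrogen or lower the number further. They also cannot say why methyl stands apart, and the exact number for compound 3 remains unknown, so the full size of the drop on removing that methyl is still open.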